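Fluoro for Methoxy at a Second Place on the Ring

The source may report more compounds than this note shows. Statements on the series, on what has been measured and on what is new or still open speak of the compounds shown alone.

Compound 1 `CCC1=C(O)c2c(oc(-c3ccc(OC)cc3)cc2=O)C(CC)(CC)C1=O`, compound 2 `CCC1=C(O)c2c(oc(-c3ccc(F)cc3)cc2=O)C(CC)(CC)C1=O` and compound 3 `CCC1=C(O)c2c(oc(-c3ccccc3OC)cc2=O)C(CC)(CC)C1=O` share one core and differ only in the aromatic group attached to it. In a functional assay on KB cells (Homo sapiens) for antiproliferative activity, read by sulforhodamine B assay, with a stated time of 3 days (a higher number here means that more compound is needed for the effect, a lower number that less compound is needed), compound 1 gives 17.7 uM. In this assay compound 2 gives 33 uM, and in this assay compound 3 gives 40.8 uM.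

The change from compound 1 to compound 2 is fluoro in place of methoxy on an aromatic carbon. In this assay it made a 1.9-fold higher number from compound 1 to compound 2 (0.27 log units; within the scatter). Compound 3 carries a different core than compound 1: 2-methoxyphenyl in place of 4-methoxyphenyl on an aromatic carbon. That rearrangement brought a 2.3-fold higher number from compound 1 to compound 3 (0.36 log units; beyond the scatter), while between compound 2 and compound 3 there is a 1.2-fold higher number from compound 2 to compound 3 (0.09 log units; within the scatter).

Compound 4 `CCC1=C(O)c2c(oc(-c3ccccc3F)cc2=O)C(CC)(CC)C1=O` has not yet been measured. It differs from compound 3 by fluoro in place of methoxy on an aromatic carbon. Going by the values given here, this is the same kind of change as the one from compound 1 to compound 2, but not the same: there the fluoro sat para to a large group, here it sits ortho to a large group. Only the earlier pair gives a guide, and its step lay within the usual scatter, so the expected step in this assay from compound 3 to compound 4 is a 1.5-fold higher number from compound 3 to compound 4 (0.17 log units; within the scatter), resting on a 1.9-fold higher number from compound 1 to compound 2 (0.27 log units; within the scatter). Compound 4 is therefore expected to give about 60 uM in this assay. Its estimated range runs from 25 uM to 150 uM for compound 4.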

Compound 4, concentration for half-maximal effect: > 56.2 uM
Compound 4 gave a limit, no number; the forecaster's own chance of this, stated with the estimate: 10%; the middle value lies beyond the limit too.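

The result for compound 4 in this assay is a limit of the assay and not a number: the limit of > 56.2 uM in this assay, at which 1 of the 4 values shown sits. Carried over to the compound with the ortho group, fluoro in place of methoxy gives an at least 1.3-fold higher number from compound 3 to compound 4 (0.13 log units; that floor lies within the scatter), so this step is known only as a floor and its true size stays unknown, which means the two cases can be set side by side but not shown to match or to differ: the same change on two cores in this assay, a 1.9-fold higher number (0.27 log units; within the scatter) from compound 1 to compound 2 and an at least 1.3-fold higher number (0.13 log units; that floor lies within the scatter) from compound 3 to compound 4; the limit leaves it open whether they differ. The two remaining steps are also floors, an at least 1.7-fold higher number from compound 2 to compound 4 (0.23 log units; that floor lies within the scatter) for 2-fluorophenyl in place of 4-fluorophenyl and an at least 3.1-fold higher number from compound 1 to compound 4 (0.50 log units; beyond the scatter) for 2-fluorophenyl in place of 4-methoxyphenyl; only the last clears the scatter, and two pairs of compounds are too few to make a rule of how this change carries from one core to another.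

The compounds shown leave open how far the true value of compound 4 lies past its limit, and so how large the step from methoxy to fluoro really is at this place on the ring. They also leave open how the number would move with a different group on the same aromatic carbon, such as an amine or a carboxylic acid.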